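From 4-hydroxyphenyl to 3,4,5-trimethoxyphenyl on compound 1

This account rests on a few compounds, and the source may have more. Where it says the series, first, only, none or still open, it means among the compounds named here.

Within the data shown here, in a functional assay on HCT-116 cells (Homo sapiens) for inhibition, read by sulforhodamine B assay, with a stated time of 48 h, tested at 50 uM (on this read-out higher numbers stand for more inhibition of growth at the one concentration tested and lower numbers for less inhibition of growth), compound 1 `COc1ccc([C@@H]2C/C(=N/OCc3cn(-c4ccc(O)cc4)nn3)c3cc(CC=C(C)C)c(OC)cc3O2)cc1` gives 65% as the lower of the two numbers known so far. The higher belongs to compound 2 `COc1cc2c(cc1CC=C(C)C)/C(=N/NC(N)=O)C[C@@H](c1ccc(O)cc1)O2` at 87% and the gap between them lies beyond the scatter. Compound 3 `COc1ccc([C@@H]2C/C(=N/OCc3cn(-c4cc(OC)c(OC)c(OC)c4)nn3)c3cc(CC=C(C)C)c(OC)cc3O2)cc1` differs from compound 1 3,4,5-trimethoxyphenyl in place of 4-hydroxyphenyl on an aromatic nitrogen by 3,4,5-trimethoxyphenyl in place of 4-hydroxyphenyl on an aromatic nitrogen. Among the measured compounds shown here, no measured pair shows this change, so the expected step of a number 2 percentage points lower from compound 1 to compound 3 (within the scatter) in this assay is none beyond the scatter. For compound 3 the estimated value is 63% within an expected range from 45% to 80% (an expectation, not a measurement).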

Compound 3, percent growth inhibition at one concentration: 29%
Compound 3: the middle estimate sits 34 percentage points above what was measured; the measured number lies below the stated range.
By their numbers in this assay, from the lowest: compound 3; then compound 1; then compound 2.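

In this assay, the group on the aromatic nitrogen of the five-membered ring proves to matter: 3,4,5-trimethoxyphenyl in place of 4-hydroxyphenyl gives a number 36 percentage points lower from compound 1 to compound 3 (beyond the scatter), a large step. The earlier pair, compound 1 and compound 2, differ in more than one place and could not show this. Nothing available accounts for the step. The compounds shown leave open whether it goes with losing the hydroxyl or with gaining the methoxy groups; a plain phenyl or a 4-methoxyphenyl on that nitrogen would separate the two.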